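This account rests on a few compounds, and the source may have more. Where it says the series, first, only, none or still open, it means among the compounds named here.

In a functional assay on Ehrlich cells (Mus musculus) for cytotoxicity, tested at 50 ug/mL (on this read-out lower numbers stand for a weaker effect and higher numbers for a stronger effect at the one concentration tested), compound 2 `COc1cc(N2C(N)=C(C#N)C(c3ccc(OC)c4ccccc34)C3=C2CC(C)(C)CC3=O)cc(OC)c1OC` gives 40%, the highest of the two numbers obtained. Within the data shown here, its nearest neighbour is compound 1 `COc1cc(N2C(N)=C(C#N)C(c3c(O)ccc4ccccc34)C3=C2CC(C)(C)CC3=O)cc(OC)c1OC`, which in this assay gives 15%; the one measured step, a number 25 percentage points higher from compound 1 to compound 2 (beyond the scatter), arises from exchanging one naphthyl substituent for another on the same saturated ring carbon. Compound 3 `COc1cc(N2C(N)=C(C#N)C(c3cccc([N+](=O)[O-])c3)C3=C2CC(C)(C)CC3=O)cc(OC)c1OC` departs from compound 2 by a larger change: 3-nitrophenyl in place of 4-methoxynaphthalen-1-yl on a saturated ring carbon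

Among the measured compounds shown here, no measured step exchanges a two-ring aromatic group for a single ring at this position, so the step from compound 1 to compound 2 bears on the new change only loosely: it shows that altering the aryl group on this carbon can move the read-out beyond the scatter, without fixing a direction. Compound 3 is therefore expected to fall near the middle of the two measured numbers, with a wide band, at 25% (range 5% to 55%), which means an expected step of a number 15 percentage points lower from compound 2 to compound 3 (beyond the scatter).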

Compound 3, a percentage reported as activity, at one concentration (the size of the read-out at that concentration, not a potency): 30%
For compound 3 the middle estimate is 5 percentage points below the measured one; the measured number falls inside the stated range.
By their numbers in this assay, from the lowest: compound 1; then compounds 3 and 2 (each within the scatter of the next).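

In this assay the exchange of 4-methoxynaphthalen-1-yl for 3-nitrophenyl on this saturated ring carbon gives a number 10 percentage points lower from compound 2 to compound 3 (within the scatter) and so shows that a single aromatic ring here can give a read-out that the scatter does not separate from that of the two-ring group. Set against 2-hydroxynaphthalen-1-yl, the same 3-nitrophenyl group gives a number 15 percentage points higher from compound 1 to compound 3 (beyond the scatter) so among these three compounds a naphthyl group does not by itself decide the number, and the lowest value belongs to the hydroxylated naphthyl group alone. Nothing at hand gives a reason for these numbers.

Going by these compounds, it remains open what an unsubstituted phenyl, an aminophenyl or a carboxyphenyl group would give on this carbon. Also open, on these data alone, is whether the number depends on where the nitro group sits on the phenyl ring.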